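The source may hold more compounds than are shown below. What is called first, only, known or untested is meant among the compounds shown, and "the series" means these compounds.

Values in a functional assay on MCF7 cells (Homo sapiens) for inhibition, read by MTT assay, with a stated time of 72 h; a lower number here means a stronger inhibitor, a higher number a weaker inhibitor:
compound 1 `COc1cc(NC(C)CCCNC(=O)NNC(=O)Nc2ccc(Cl)cc2)c2ncccc2c1`: 180 nM
compound 2 `COc1cc(NC(C)CCCNC(=O)NNC(=O)Nc2ccc(C(F)(F)F)cc2)c2ncccc2c1`: 100 nM
compound 3 `COc1cc(NC(C)CCCNC(=O)Nc2cc(C(F)(F)F)cc(C(F)(F)F)c2)c2ncccc2c1`: 1600 nM

Compound 1 stands within the scatter of compound 2, while compound 3 gives a clearly higher number than both. Compound 4 `COc1cc(NC(C)CCCNC(=O)Nc2ccc(Cl)cc2)c2ncccc2c1` departs from compound 1 as follows: 4-chlorophenyl in place of ((4-chlorophenyl)carbamoyl)amino on an amide-type nitrogen. Going by the values given here, the only measured step, a 1.8-fold lower number from compound 1 to compound 2 (0.26 log units; within the scatter), concerns the substituent on the aromatic ring and leaves this part untouched, so it gives no direct size. Like compound 4, compound 3 carries its aromatic ring on an amide-type nitrogen, and compound 3 gives 1600 nM, though its ring substituents differ. A higher number beyond the scatter is therefore expected in this assay. The expected step is a 5.0-fold higher number from compound 1 to compound 4 (0.70 log units; beyond the scatter). Compound 4 is estimated at 900 nM, within an expected range of 300 nM to 2500 nM.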

Compound 4, half-maximal inhibitory concentration: 12000 nM
The estimate for compound 4 lay 13-fold (1.12 log units) below the measured number; the measured number lies above the stated range.
By their numbers in this assay, from the lowest: compounds 2 and 1 (each within the scatter of the next); then compound 3; then compound 4.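

On the amide-type nitrogen, 4-chlorophenyl in place of ((4-chlorophenyl)carbamoyl)amino gives a 67-fold higher number from compound 1 to compound 4 (1.82 log units; beyond the scatter) in this assay, so this position carries a large step, unlike the change of aromatic substituent seen earlier. The 4-chlorophenyl ring is present in both compounds, while the leaving group also holds 2 hydrogen-bond donors and 1 hydrogen-bond acceptor and the entering group holds none. No available measurement accounts for the size of this step.

Which part of ((4-chlorophenyl)carbamoyl)amino matters remains open. Also open, as far as these compounds go, is whether a longer chain or a carboxylic acid on this nitrogen would give numbers nearer that of compound 1.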